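The source may hold more compounds than are shown below. What is called first, only, known or untested is meant among the compounds shown, and "the series" means these compounds.

Measured compounds:
compound 1 `CCCn1c(=O)[nH]c2nc(-c3ccc(S(=O)(=O)N4CCN(Cc5cccc(C)c5)CC4)cc3)[nH]c2c1=O`: 795 nM
compound 2 `CCCn1c(=O)[nH]c2nc(-c3ccc(S(=O)(=O)N4CCN(c5ccccc5)CC4)cc3)[nH]c2c1=O`: 364 nM

In an assay on CHO cells for displacement of a labelled ligand from adenosine receptor A1 (Homo sapiens), read by scintillation counting, with a stated time of 90 min, in the presence of a further agent that is not named here (a lower number here means a stronger inhibitor, a higher number a weaker inhibitor), compound 2 gives 364 nM, the lowest of the two numbers measured. Compound 1 gives 795 nM in this assay. Going by the values given here, the single measured step, a 2.2-fold lower number from compound 1 to compound 2 (0.34 log units; beyond the scatter), lies beyond the usual scatter and comes from exchanging the whole group on the amine nitrogen of the ring.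

Compound 3 `CCCn1c(=O)[nH]c2nc(-c3ccc(S(=O)(=O)N4CCN(c5ccccc5Cl)CC4)cc3)[nH]c2c1=O` keeps the phenyl of compound 2 and differs from it only by chloro in place of hydrogen on an aromatic carbon. Among the compounds with values here, no measured step adds a single substituent to that phenyl, so the one step known, a 2.2-fold lower number from compound 1 to compound 2 (0.34 log units; beyond the scatter), does not bear directly on this change; it only shows that the group on the amine nitrogen matters modestly. With nothing of the same kind to lean on, the expected step of a 1.0-fold lower number from compound 2 to compound 3 (0.02 log units; within the scatter) is small, within the scatter, in no particular direction. Compound 3 is therefore expected to give about 350 nM in this assay, with a likely range from 140 nM to 900 nM.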

Compound 3, inhibition constant: > 1000 nM
Compound 3: no number, only a limit; the forecaster's own chance of this, stated with the estimate: 3%; middle value at least 2.8-fold (0.45 log units) away from the limit.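

In this assay compound 3 gives > 1000 nM, which is a limit of the assay and not a number: the limit of > 1000 nM in this assay, at which 1 of the 3 values shown sits. Even so, the step can be read: placing a single chloro on the phenyl, ortho to a large group, gives an at least 2.7-fold higher number from compound 2 to compound 3 (0.43 log units; beyond the scatter), so this position on the phenyl does not tolerate every substituent equally. Against the 3-methylbenzyl group, the 2-chlorophenyl group gives an at least 1.2-fold higher number from compound 1 to compound 3 (0.09 log units; that floor lies within the scatter), and as that floor lies within the scatter, the order of these two compounds stays unsettled.

The compounds shown leave open whether this weakening belongs to chloro itself or to its place on the ring. A methyl or methoxy group at the same place, or a chloro elsewhere on the phenyl, would separate these two readings.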